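Bromo in the para-substituted phenyl of the triazole arm

The source may hold more compounds than are shown below. What is called first, only, known or untested is meant among the compounds shown, and "the series" means these compounds.

Measured compounds:
compound 1 `O=C1NC(=O)/C(=C/c2ccc(OCCSc3nnc(-c4ccccc4)[nH]3)cc2)S1` gives 22.9%
compound 2 `O=C1NC(=O)/C(=C/c2ccc(OCCSc3nnc(Cc4ccccc4)[nH]3)cc2)S1` gives 34.4%
compound 3 `O=C1NC(=O)/C(=C/c2ccc(OCCSc3nnc(-c4ccc([N+](=O)[O-])cc4)[nH]3)cc2)S1` gives 18%

In a functional assay on the whole organism (plasma, strain Wistar) with Rattus norvegicus as the target, with a stated time of 15 days, at a dose of 100 mg/kg by the oral route (on this read-out lower numbers stand for a weaker effect and higher numbers for a stronger effect at the one dose given), compound 1 stands second highest of the three numbers; its gap to compound 3 lies within the scatter, while compound 2 lies above it by a step beyond the scatter, a number 11.5 percentage points higher from compound 1 to compound 2 (beyond the scatter). The unmeasured compound 4 `O=C1NC(=O)/C(=C/c2ccc(OCCSc3nnc(-c4ccc(Br)cc4)[nH]3)cc2)S1` differs from compound 1 by bromo in place of hydrogen on an aromatic carbon, on an aromatic carbon of a six-membered aromatic ring of carbon only, para to a large group.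

Among the compounds with values here, one measured step touches the same place: a number 4.9 percentage points lower from compound 1 to compound 3 (within the scatter), a change on that ring that stayed within the scatter. The step of a number 16.4 percentage points lower from compound 2 to compound 3 (beyond the scatter) changes the whole group and so speaks less directly to a single ring substituent. A substituent at this position therefore gives no ground to expect a step beyond the scatter in this assay, in either direction.

For compound 4 the value in this assay is expected to be about 22%, within 10% to 35%, a step of a number 0.9 percentage points lower from compound 1 to compound 4 (within the scatter) that is estimated to stay within the scatter.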

Compound 4, a percentage reported as activity, at one dose (the size of the read-out at that dose, not a potency): 28.5%
For compound 4 the middle estimate is 6.5 percentage points below the measured one; measured number inside the range.
By their numbers in this assay, from the lowest: compounds 3, 1, 4 and 2 (each within the scatter of the next, the first and the last beyond it).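

In this assay, bromo in place of hydrogen on this ring gives a number 5.6 percentage points higher from compound 1 to compound 4 (within the scatter), so a second para substituent, after nitro, also stays close to the unsubstituted phenyl of compound 1. The two substituents can still be told apart: bromo in place of nitro gives a number 10.5 percentage points higher from compound 3 to compound 4 (beyond the scatter), a modest step even though each lies within the scatter of compound 1, while the change from the benzyl arm to the 4-bromophenyl arm gives a number 5.9 percentage points lower from compound 2 to compound 4 (within the scatter), which the nitro analogue of that step did not. No measurement of any kind accompanies these values that could account for them.

Going by these compounds, with only nitro and bromo at this place, it remains open whether any substituent there can move the value beyond the scatter of compound 1. An amine, a methoxy or a carboxylic acid at the same place, or bromo on the phenyl of the benzyl arm of compound 2, would address this.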